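Taking the bromo off compound 2

This account rests on a few compounds, and the source may have more. Where it says the series, first, only, none or still open, it means among the compounds named here.

compound 1 `Cc1ccc(S/C(=C/c2ccc(Br)cc2)C(=O)c2ccc(Cl)cc2)cc1`: 25000 nM
compound 2 `Cc1ccc(S/C(=C/c2c[nH]c3ccc(Br)cc23)C(=O)c2ccc(Cl)cc2)cc1`: 1000 nM

In a functional assay on DU-145 cells (Homo sapiens) for inhibition, read by trypan blue exclusion, with a stated time of 96 h (on this read-out lower numbers stand for stronger inhibition of growth and higher numbers for weaker inhibition of growth), compound 2 gives 1000 nM, the lower of the two numbers. Compound 1 gives 25000 nM. The gap between these two compounds lies beyond the usual scatter. Compound 3 `Cc1ccc(S/C(=C/c2c[nH]c3ccccc23)C(=O)c2ccc(Cl)cc2)cc1` differs from compound 2 in one place: hydrogen in place of bromo on an aromatic carbon. Among the measured compounds shown here, no measured pair shows this change alone, so any forecast is uncertain. A modest rise in the number, meaning somewhat weaker inhibition of growth, is expected. The expected size is a 2.0-fold higher number from compound 2 to compound 3 (0.30 log units; within the scatter). Compound 3 is estimated at 2000 nM, with an expected range of 600 nM to 8000 nM.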

Compound 3, concentration for 50% growth inhibition: 10000 nM
Compound 3: middle estimate off by 5.0-fold (0.70 log units), on the low side, outside the stated range (above it).
By their numbers in this assay, from the lowest: compound 2; then compound 3; then compound 1.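

In this assay the bromo on this aromatic carbon matters a great deal: hydrogen in its place gives a 10-fold higher number from compound 2 to compound 3 (1.00 log units; beyond the scatter), so inhibition of growth is clearly weaker without it. Even without that bromo, 1H-indol-3-yl still does better than 4-bromophenyl, with a 2.5-fold lower number from compound 1 to compound 3 (0.40 log units; beyond the scatter). Nothing available explains the size of either step.

From the compounds shown here alone, it remains open whether bromine itself is needed on this carbon, or whether a chloro, a methoxy or an amine there would keep the number of compound 2.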